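The source may report more compounds than this note shows. Statements on the series, on what has been measured and on what is new or still open speak of the compounds shown alone.

Measured in a functional assay on MDA-MB-231 cells (Homo sapiens) for antiproliferative activity, with a stated time of 4 days; on this read-out lower numbers stand for stronger inhibition and higher numbers for weaker inhibition:
- compound 1 `CCCCc1ccc2[nH]c(-c3ccc(C)cc3)c(C=O)c2c1`: 34 nM
- compound 2 `CCCCc1ccc2[nH]c(-c3ccc(CC)cc3)c(C=O)c2c1`: 27 nM
- compound 3 `CCCCc1ccc2[nH]c(-c3ccc(F)cc3)c(C=O)c2c1`: 350 nM

Compound 3 has the highest number of the three, so it is the weakest inhibitor here. Compound 4 `CCCCc1ccc2[nH]c(-c3ccc(C(F)(F)F)cc3)c(C=O)c2c1` differs from it in one group: trifluoromethyl in place of fluoro on an aromatic carbon. Two large steps bear on this change, a 10-fold higher number from compound 1 to compound 3 (1.01 log units; beyond the scatter) and a 13-fold higher number from compound 2 to compound 3 (1.11 log units; beyond the scatter), both of which show fluoro giving up much of the activity seen with methyl or ethyl. Methyl and ethyl themselves differ little, a 1.3-fold lower number from compound 1 to compound 2 (0.10 log units; within the scatter). Among the measured compounds shown here, no measured compound carries trifluoromethyl, so only a partial recovery can be expected in this assay, towards lower numbers. The expected size of the change is a 3.9-fold lower number from compound 3 to compound 4 (0.59 log units; beyond the scatter). For compound 4 the estimate is 90 nM, with an expected range of 25 nM to 350 nM.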

Compound 4, half-maximal inhibitory concentration: 33 nM
For compound 4 the middle estimate is 2.7-fold (0.44 log units) above the measured one; the measured number falls inside the stated range.
By their numbers in this assay, from the lowest: compounds 2, 4 and 1 (each within the scatter of the next); then compound 3.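

In this assay trifluoromethyl recovers at this position what fluoro gave up, with an 11-fold lower number from compound 3 to compound 4 (1.03 log units; beyond the scatter) as the step. Trifluoromethyl also stands level with methyl and ethyl, with a 1.0-fold lower number from compound 1 to compound 4 (0.01 log units; within the scatter) and a 1.2-fold higher number from compound 2 to compound 4 (0.09 log units; within the scatter) as the steps, so of the four groups shown on this aromatic carbon only fluoro stands apart. From the compounds shown here alone, how an amine, a carboxylic acid or a longer chain would fare at this position stays open. Nothing measured here says why fluoro alone differs from the other three groups.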